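A few compounds are considered here, and "the series" means these few. Any claim that something is new, unique, unknown or untested is made for them only; others in the source may bear on it.

Measured compounds, with their values in a functional assay on SK-HEP1 cells (Homo sapiens) for inhibition, read by MTT assay, with a stated time of 72 h; a lower number here means a stronger inhibitor, a higher number a weaker inhibitor:
- compound 1, `CNC(=O)CCCCCCCn1nc(-c2ccc3oc(N)nc3c2)c2c(N)ncnc21`: 10700 nM
- compound 2, `Nc1ncnc2c1c(-c1cnc3[nH]ccc3c1)nn2CCCCCCCCCC(=O)NO`: 23500 nM
- compound 3, `Nc1ncnc2c1c(-c1cnc3[nH]ccc3c1)nn2CCCCCC(=O)NO`: gives only a limit, > 150000 nM

Compound 1 holds the lowest of the two numbers in this assay; compound 2 sits at a higher number than compound 1, beyond the scatter. The value of compound 3 is a limit of the assay, not a number (the limit of > 150000 nM in this assay, at which 1 of the 3 values shown sits).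

Compound 4, `Nc1nc2cc(-c3nn(CCCCCCC(=O)NO)c4ncnc(N)c34)ccc2o1`, shares its core with compound 1 and differs from it only in the chain cap: hydroxycarbamoyl in place of (methylcarbamoyl)methyl on a saturated chain carbon, six bonds along the chain from an aromatic nitrogen.

Among the compounds with values here, the one measured step that touches the cap region is an at least 6.3-fold higher number from compound 2 to compound 3 (0.80 log units; beyond the scatter), where the chain carrying the hydroxycarbamoyl group was cut by four carbons on a different core. Within the data shown here, the change from compound 1 to compound 4 shortens the chain by only one carbon while exchanging the methylcarbamoyl end for the hydroxycarbamoyl end, a pairing that no measured step covers. The expected step is therefore small, a 1.3-fold lower number from compound 1 to compound 4 (0.13 log units; within the scatter), with wide uncertainty in either direction. Compound 4 is estimated at 8000 nM, within 2500 nM to 25000 nM.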

Compound 4, half-maximal inhibitory concentration: 2690 nM
Compound 4: middle estimate off by 3.0-fold (0.47 log units), on the high side; low and high end bracket the measured number.
By their numbers in this assay, from the lowest: compound 4; then compound 1; then compound 2. At a limit, above all of these: compound 3.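

In this assay, hydroxycarbamoyl in place of (methylcarbamoyl)methyl gives a 4.0-fold lower number from compound 1 to compound 4 (0.60 log units; beyond the scatter), so on the core of compound 1 a change at this position, six bonds along the chain from an aromatic nitrogen, moves the number beyond the scatter. The earlier step in this region, an at least 6.3-fold higher number from compound 2 to compound 3 (0.80 log units; beyond the scatter), altered chain length with the hydroxycarbamoyl end kept on another core, whereas this step also replaces the end group. Nothing among the data shown accounts for the size or direction of this step.

From the compounds shown here alone, whether the step belongs to the hydroxycarbamoyl end or to the shorter chain stays open, as the two changes travel together here. A carboxylic acid end on the chain of compound 4, or a longer chain ending in hydroxycarbamoyl on the same core, would help separate the two.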